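The source may report more compounds than this note shows. Statements on the series, on what has been measured and on what is new or still open speak of the compounds shown alone.

For the measured compounds named here, in a functional assay on A2780 cells (Homo sapiens) for antiproliferative activity (on this read-out higher numbers stand for weaker inhibition and lower numbers for stronger inhibition), compound 1 (`Cc1ccc2c(c1C)CN(C(=O)N(C)CCCN(C)C)CC2c1ccccc1`) gives 1210 nM and is the only compound here with a number. Compound 2 (`CN(C)C(=O)N1Cc2cc(F)ccc2C(c2cccc(O)c2)C1`) stands at "not determined" (no result reported) on this read-out, so it offers no single number. Compound 3 (`COc1ccc2c(c1)CN(C(=O)N(C)C)CC2c1cccc(O)c1`) departs from compound 2 through methoxy in place of fluoro on an aromatic carbon. Going by the values given here, no measured step guides the expectation for this change in this assay, and compound 1 at 1210 nM serves as the sole, distant anchor. Compound 3 is expected near 2000 nM with 250 nM to 15000 nM as the estimated range.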

Compound 3, half-maximal inhibitory concentration: 402 nM
The estimate for compound 3 lay 5.0-fold (0.70 log units) above the measured number; measured number inside the range.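

Compound 2 has no number in this assay and compound 1 differs from compound 3 in more than one place, so no step can be read for compound 3. What methoxy in place of fluoro does in this assay stays open, and no evidence shown bears on the result for compound 3.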